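Amide variation on the shared core: outlook for compound 3

The compounds below may be only part of what the source reports. "The series", "measured", "known", "first", "only" and "open" are said of these compounds alone.

Measured so far:
compound 1, `CC1CCC(C(=O)N2CC(c3nc(-c4cccc(Cl)c4)no3)C2)CC1`: in an assay on HEK293 cells for negative allosteric modulation of metabotropic glutamate receptor 5 (Homo sapiens), read by FLIPR (on this read-out lower numbers stand for stronger inhibition and higher numbers for weaker inhibition), compound 1 gives > 10000 nM, a limit of the assay.
compound 2, `O=C(N1CCCCC1)N1CC(c2nc(-c3cccc(Cl)c3)no2)C1`: in this assay compound 2 gives > 10000 nM, a limit of the assay.

Compound 2 stands at the limit, as does every value shown so far (the limit of > 10000 nM in this assay, at which 2 of the 2 values shown sit). Within the data shown here, the only measured step, a step that the two limits leave unreadable from compound 1 to compound 2, lies between two limits and gives no readable size. Compound 3, `O=C(C1CCCO1)N1CC(c2nc(-c3cccc(Cl)c3)no2)C1`, differs from compound 2 by oxolan-2-yl in place of piperidin-1-yl on a carbonyl carbon. Among the measured compounds shown here, no measured step bears on this change with a readable size, so the direction in this assay cannot be drawn from the series. Compound 3 is therefore expected at the limit as well, estimated at 10000 nM within 3000 nM to 30000 nM. The expected step is a number no higher from compound 2 to compound 3 (the limit leaves the size open), nothing beyond the scatter.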

Compound 3, half-maximal inhibitory concentration: 890 nM
The estimate for compound 3 lay 11-fold (1.05 log units) above the measured number; the measured number lies below the stated range.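

On the carbonyl carbon, oxolan-2-yl gives the first number inside the range of this assay, with an at least 11-fold lower number from compound 2 to compound 3 (1.05 log units; beyond the scatter) and an at least 11-fold lower number from compound 1 to compound 3 (1.05 log units; beyond the scatter). Both steps start from a limit, so their full size remains unread: the limit of > 10000 nM in this assay, at which 2 of the 3 values shown sit. The position therefore responds to the group it carries, and the two groups at the limit include 4-methylcyclohexyl, which also joins the carbonyl through a ring carbon.

Going by these compounds, whether the gain follows the ring oxygen, the hydrogen-bond acceptor counted there or the five-membered ring stays open. Cyclopentyl or methoxymethyl on the same carbonyl carbon would bear on this.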